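A New Pyridyl Ether on the Shared Core

The source may hold more compounds than are shown below. What is called first, only, known or untested is meant among the compounds shown, and "the series" means these compounds.

Three compounds have been measured in a functional assay on CHO cells for positive allosteric modulation of metabotropic glutamate receptor 2 (Homo sapiens), read by scintillation counting and GTPgammaS binding, with a stated time of 30 min; on this read-out lower numbers stand for smaller maximal responses and higher numbers for larger maximal responses:

Compound 1 `CC(C)CCn1ccc(-c2ccccc2)c(C#N)c1=O` gives 117%
Compound 2 `CC(C)CCn1ccc(-c2ccc(Oc3cccnc3)cc2)c(C#N)c1=O` gives 231%
Compound 3 `CC(C)CCn1ccc(-c2ccc(Oc3ccncc3)cc2)c(C#N)c1=O` gives 245%

Compound 3 stands highest of the three in this assay. Its nearest neighbour is compound 2, and the step of a number 14 percentage points higher from compound 2 to compound 3 (beyond the scatter) is beyond the scatter but modest. The distance to compound 1 is far larger: a number 128 percentage points higher from compound 1 to compound 3 (beyond the scatter), a rise that mirrors the step of a number 114 percentage points higher from compound 1 to compound 2 (beyond the scatter). Adding either pyridyl ether to the bare ring of compound 1 therefore lifts the maximal response strongly, while the choice between the two pyridyl attachment points matters much less.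

The next compound, compound 4 `Cc1ncccc1Oc1ccc(-c2ccn(CCC(C)C)c(=O)c2C#N)cc1`, differs from compound 3 in one place: 2-methylpyridin-3-yl in place of pyridin-4-yl on an oxygen on an aromatic ring.

Among the compounds with values here, the steps that bear on this change are the large ones from compound 1, which show that a pyridyl ether of either kind gives a high maximal response, and the modest one between compound 2 and compound 3, which shows that a pyridin-3-yl ether sits a little lower than a pyridin-4-yl ether. Within the data shown here, compound 4 carries a pyridin-3-yl ether again, now with a methyl group, for which no measured step exists. The step of a number 15 percentage points lower from compound 3 to compound 4 (beyond the scatter) is therefore expected to be small, likely a modest fall toward the level of compound 2. Compound 4 is estimated at 230% in this assay, within a range of 190% to 265%.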

Compound 4, largest response reached (Emax), in percent of the reference or control that the assay uses: 256%
The estimate for compound 4 lay 26 percentage points below the measured number; measured number inside the range.
By their numbers in this assay, from the lowest: compound 1; then compound 2; then compound 3; then compound 4.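

Adding a methyl group to the pyridyl ring of compound 2 gives a number 25 percentage points higher from compound 2 to compound 4 (beyond the scatter) in this assay, the first measured step for a group placed on the pyridyl ring itself, and it shows that this added methyl raises the maximal response rather than lowering it. Replacing pyridin-4-yl with 2-methylpyridin-3-yl on the oxygen gives a number 11 percentage points higher from compound 3 to compound 4 (beyond the scatter), so the methylated pyridin-3-yl ether surpasses the pyridin-4-yl ether, although the unmethylated pyridin-3-yl ether of compound 2 does not, while the full (2-methylpyridin-3-yl)oxy group gives a number 139 percentage points higher from compound 1 to compound 4 (beyond the scatter) over the bare ring. No measurement is available that would explain this effect of the methyl group.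

The compounds shown leave open whether an ethyl group, a methoxy group or a chlorine atom in place of this methyl would give a similar response, and whether a methyl group on the pyridin-4-yl ether would also raise it. On these data alone, the chain on the shared core is the same in all four compounds, so the effect of a longer chain or a cyclopropylmethyl group there also remains open.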